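The source may hold more compounds than are shown below. What is called first, only, known or untested is meant among the compounds shown, and "the series" means these compounds.

Measured compounds in an assay on isolated protein (strain albino) for antagonist activity at Voltage-dependent L-type calcium channel subunit alpha-1C (Cavia porcellus); a higher number here means a weaker inhibitor, a lower number a stronger inhibitor:
compound 1 `COCCOC(=O)C1=C(C)NC(C)=C(C(=O)OC)C1c1cnc(SC)n1Nc1ccccc1` gives 9.65 nM
compound 2 `COC(=O)C1=C(C)NC(C)=C(C(=O)OCc2ccccc2)C1c1cnc(SC)n1Nc1ccccc1` gives 2.21 nM

Among the compounds with values here, compound 1 stands at the higher of the two numbers in this assay; the only step in hand, a 4.4-fold lower number from compound 1 to compound 2 (0.64 log units; beyond the scatter), concerns the other ester of the shared core. Compound 3 `COCCOC(=O)C1=C(C)NC(C)=C(C(=O)OC(C)C)C1c1cnc(SC)n1Nc1ccccc1` differs from compound 1 by isopropyl in place of methyl on an oxygen next to a carbonyl group. Within the data shown here, no measured step touches this oxygen, so the shift is expected to stay small, within or just beyond the scatter, with direction uncertain. The expected move is a 1.4-fold lower number from compound 1 to compound 3 (0.14 log units; within the scatter). Compound 3 is therefore estimated at 7 nM, with a range from 2.5 nM to 20 nM.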

Compound 3, half-maximal inhibitory concentration: 53.4 nM
Compound 3: middle estimate off by 7.6-fold (0.88 log units), on the low side; the measured number lies above the stated range.
By their numbers in this assay, from the lowest: compound 2; then compound 1; then compound 3.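

In this assay isopropyl in place of methyl on an oxygen next to a carbonyl group gives a 5.5-fold higher number from compound 1 to compound 3 (0.74 log units; beyond the scatter) so this ester position responds to the change and does not tolerate it freely. The direction is opposite to that at the other ester, where the change gives a 4.4-fold lower number from compound 1 to compound 2 (0.64 log units; beyond the scatter) and the two ester positions therefore cannot be read as interchangeable. No measurement at hand accounts for the rise in the number. With only methyl and isopropyl at this oxygen, the compounds shown leave open how ethyl or benzyl would read there.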